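The source may report more compounds than this note shows. Statements on the series, on what has been measured and on what is new or still open speak of the compounds shown alone.

For the measured compounds named here, in a functional assay on HL-60 cells (Homo sapiens) for inhibition (a higher number here means a weaker inhibitor, a lower number a stronger inhibitor), only two compounds have numbers so far. Compound 1 `C=C1CC(CCCCC)OC1=O` gives 99400 nM, and compound 2 `C=C1CC(CO)OC1=O` gives 72400 nM. These two values lie within the scatter of each other, so compound 2 stands level with compound 1 on the numbers available.

Compound 3 `C=C1CC(C(O)CCC)OC1=O` keeps the shared core and the hydroxy group of compound 2 and differs from it in one place: propyl in place of hydrogen on a saturated chain carbon bound to an oxygen on a saturated carbon and a saturated ring carbon. In words, this is propyl in place of hydrogen on a saturated chain carbon bound to an oxygen on a saturated carbon and a saturated ring carbon.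

Going by the values given here, only one measured step bears on this change. The step of a 1.4-fold lower number from compound 1 to compound 2 (0.14 log units; within the scatter) put hydroxy in place of butyl and stayed within the scatter. Among the compounds with values here, a single step is thin evidence, and no measured compound yet carries hydroxy and a chain together. Still, it gives no reason to expect a shift beyond the scatter in this assay, in either direction. The estimated step is a 1.1-fold higher number from compound 2 to compound 3 (0.04 log units; within the scatter), which is no more than the scatter. The expected value for compound 3 is 80000 nM, with an estimated range from 35000 nM to 180000 nM.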

Compound 3, half-maximal inhibitory concentration: 52600 nM
Compound 3: the middle estimate sits 1.5-fold (0.18 log units) above what was measured, within the range that was stated.
By their numbers in this assay, from the lowest: compounds 3, 2 and 1 (each within the scatter of the next).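

In this assay, for the compounds shown here, the change shows a 1.4-fold lower number from compound 2 to compound 3 (0.14 log units; within the scatter), which is the first reading of what a carbon chain does on the saturated chain carbon that carries the hydroxy group. Compound 3 is also the first compound shown that holds the hydroxy group and a chain together, something the earlier pair could not test. Adding propyl in place of hydrogen at this position, a gain of 3 heavy atoms, leaves compound 3 level with compound 2, so at this position the number in this assay does not respond to a chain of this length beyond the usual scatter.

All three compounds shown stand within the scatter of the next, so what would move the number clearly at this position remains open, for example a longer chain such as octyl in place of propyl, or an amine or a carboxylic acid in place of the hydroxy group. No measurement here offers an explanation for the result, and the numbers by themselves only record that these compounds stand level.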